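Swapping a Ring Nitrogen for a Methyl on the Indazole

This account rests on a few compounds, and the source may have more. Where it says the series, first, only, none or still open, it means among the compounds named here.

The two measured compounds share a triaryl alkene bearing an acrylic acid. Compound 1 `O=C(O)/C=C/c1ccc(/C(=C(/CCF)c2ccccc2)c2ccc3[nH]ncc3c2)cc1` carries a fluoroethyl chain and an indazole, and in a functional assay on MCF7 cells (Homo sapiens) for cytotoxicity, read by CellTiter-Glo, with a stated time of 5 days (on this read-out higher numbers stand for weaker inhibition and lower numbers for stronger inhibition), compound 1 gives 2.1 nM. Compound 2 `CC/C(=C(/c1ccc(/C=C/C(=O)O)cc1)c1ccc2[nH]ncc2n1)c1ccccc1` carries an ethyl chain and a ring-nitrogen-containing bicycle, and in this assay compound 2 gives 33 nM, the higher of the two numbers and well beyond the scatter from compound 1. Compound 3 `CC/C(=C(/c1ccc(/C=C/C(=O)O)cc1)c1cc2cn[nH]c2cc1C)c1ccccc1` has not been measured. It differs from compound 2 by a group of 10 heavy atoms (8 carbon, 2 nitrogen; one five-membered aromatic ring with 2 hetero atoms, one six-membered aromatic ring of carbon only) in place of a group of 9 heavy atoms (6 carbon, 3 nitrogen; one five-membered aromatic ring with 2 hetero atoms, one six-membered aromatic ring with 1 hetero atom), on a double-bonded chain carbon bound to an aromatic carbon and a double-bonded chain carbon. Among the measured compounds shown here, with no measured pair that isolates this change, the expectation leans on compound 1 with its 2.1 nM, which also holds an indazole of this kind. The step from compound 2 to compound 3 is therefore expected to be a drop of moderate size, a 5.5-fold lower number from compound 2 to compound 3 (0.74 log units; beyond the scatter). Compound 3 is estimated at 6 nM, within a range of 1.5 nM to 25 nM.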

Compound 3, half-maximal inhibitory concentration: 468 nM
Estimate against measurement, compound 3: 78-fold (1.89 log units) below; measured number outside the range, above it.
By their numbers in this assay, from the lowest: compound 1; then compound 2; then compound 3.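

In this assay, placing 6-methyl-1H-indazol-5-yl on the double-bonded chain carbon in place of the group with three nitrogens gives a 14-fold higher number from compound 2 to compound 3 (1.15 log units; beyond the scatter) and marks a large loss of inhibition. Among the compounds shown here, this is the first pair that differs in one place, and it shows that the number at this position depends strongly on which bicycle is attached. No measured property is at hand to account for the step. The change replaces a ring nitrogen with carbon and adds a methyl in one move, so the compounds shown do not separate the share of each. They also leave open how a methoxy or a chlorine in place of that methyl would read in this assay.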